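The source may hold more compounds than are shown below. What is called first, only, known or untested is meant among the compounds shown, and "the series" means these compounds.

Compound 1 `CC1=CCCC(C)(C)C1/C=C/C(=O)/C=C/c1ccccc1F` and compound 2 `CC1=CCCC(C)(C)C1/C=C/C(=O)/C=C/c1cc(C(F)(F)F)ccc1F` share one core, while compound 3 `CC1=C(/C=C/C(=O)/C=C/c2ccc(F)cc2)C(C)(C)CCC1O` and compound 4 `CC1=C(/C=C/C(=O)/C=C/c2ccc(F)c(C(F)(F)F)c2)C(C)(C)CCC1O` share another; the difference between the two cores is not broken down here. In a functional assay on LNCaP C4-2B cells (Homo sapiens) for cytotoxicity, read by MTT assay, with a stated time of 72 h (a higher number here means a weaker inhibitor, a lower number a stronger inhibitor), compound 1 gives 6000 nM, and compound 2 gives 4700 nM. The change between them is trifluoromethyl in place of hydrogen on an aromatic carbon, and it made a 1.3-fold lower number from compound 1 to compound 2 (0.11 log units; within the scatter). Compound 3 gives 4000 nM in this assay, a number within the scatter of both compound 1 and compound 2. Compound 4 carries the same kind of change on its own core, (trifluoromethyl in place of hydrogen on an aromatic carbon); the surroundings are not identical, since the entering group here sits ortho to a fluoro group and meta to a large group, whereas in compound 2 it sits meta to a large group and para to a fluoro group. Because the step of a 1.3-fold lower number from compound 1 to compound 2 (0.11 log units; within the scatter) stayed within the scatter, a step of about a 1.1-fold lower number from compound 3 to compound 4 (0.06 log units; within the scatter) is expected for compound 4 in this assay. Compound 4 is therefore estimated at 3500 nM, with a likely range from 1500 nM to 8000 nM.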

Compound 4, half-maximal inhibitory concentration: 7300 nM
Estimate against measurement, compound 4: 2.1-fold (0.32 log units) below; low and high end bracket the measured number.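

In this assay, trifluoromethyl in place of hydrogen on an aromatic carbon gave a 1.8-fold higher number from compound 3 to compound 4 (0.26 log units; within the scatter). Set side by side, the two steps give no sign that the change behaves differently on the two cores: the same change on two cores in this assay, a 1.3-fold lower number (0.11 log units; within the scatter) from compound 1 to compound 2 and a 1.8-fold higher number (0.26 log units; within the scatter) from compound 3 to compound 4, 2.3-fold (0.37 log units) apart, within the scatter of two such steps. This shows that the change stayed within the scatter on both cores, but it does not show that it carries over from one core to the other with a fixed size, as each core offers a single pair and neither step stands clear of the scatter, while in compound 4 the entering group sits ortho to a fluoro group and meta to a large group.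

The compounds shown leave open what other groups, such as a nitrile, a methoxy group or an amine, would do on this aromatic carbon. They also leave open how the difference between the two cores itself bears on the number.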